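The source may report more compounds than this note shows. Statements on the series, on what has been measured and on what is new or still open speak of the compounds shown alone.

Compound 1 `O=C1/C(=C/c2cccc(F)c2)CCc2ccccc21`: 31100 nM
Compound 2 `O=C1/C(=C/c2cccc(Br)c2)CCCc2ccccc21`: 10500 nM
Compound 3 `O=C1CCCCC/C1=C\c1ccc(F)cc1`: > 50000 nM

All three compounds were tested in a functional assay on P388 cells (Mus musculus) for inhibition; on this read-out lower numbers stand for stronger inhibition and higher numbers for weaker inhibition. Compounds 1 and 2 gave numbers. Compound 3 gave no number, only a limit, > 50000 nM.

Compound 4 `COc1ccc(/C=C2\CCCCCC2=O)cc1` differs from compound 3 by methoxy in place of fluoro on an aromatic carbon. Among the measured compounds shown here, no two measured compounds differ in one place, so the data give no direct size for such a step. In this assay, no step beyond the scatter is expected, and no direction can be favoured. The estimated step runs an at least 1.1-fold lower number from compound 3 to compound 4 (0.04 log units; that floor lies within the scatter). Compound 4 is expected at 45000 nM, with an estimated range from 20000 nM to 100000 nM.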

Compound 4, half-maximal inhibitory concentration: > 50000 nM
Compound 4 ended at the assay's limit; the forecaster's own chance of this, stated with the estimate: 55%; middle value at least 1.1-fold (0.04 log units) away from the limit.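

No step can be read from compound 3 to compound 4, because both values are limits and not numbers: the limit of > 50000 nM in this assay, at which 2 of the 4 values shown sit.

Going by these compounds, whether methoxy or fluoro gives the lower number in this assay stays open.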